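A few compounds are considered here, and "the series" means these few. Any claim that something is new, unique, unknown or untested is made for them only; others in the source may bear on it.

Measured so far:
compound 1 `COc1ccc(/C=N/NC(=O)Nc2ccc(Oc3ccnc(-c4nncn4CCN(C)C)c3)c(F)c2)c(OC)c1` — 1680 nM
compound 2 `CN(C)CCn1cnnc1-c1cc(Oc2ccc(NC(=O)N/N=C/c3ccc(O)c(Br)c3)cc2F)ccn1` — 1860 nM

In a functional assay on MKN-45 cells (Homo sapiens) for cytotoxicity, read by MTT assay, with a stated time of 72 h (a lower number here means a stronger inhibitor, a higher number a weaker inhibitor), compound 1 gives 1680 nM and compound 2 gives 1860 nM. The two sit within the scatter of each other, the step of a 1.1-fold higher number from compound 1 to compound 2 (0.04 log units; within the scatter), so compound 2 is not separated from compound 1 on these numbers.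

Compound 3 `CN(C)CCn1cnnc1-c1cc(Oc2ccc(NC(=O)N/N=C/c3ccccc3)cc2F)ccn1` carries the change (phenyl in place of 3-bromo-4-hydroxyphenyl on a carbon with a double bond to nitrogen). For the measured compounds named here, the only step that bears on it is an exchange of the same aryl group, which left this assay unchanged; no measured step shows the bare ring. The expected step is therefore a 1.2-fold higher number from compound 2 to compound 3 (0.07 log units; within the scatter), none beyond the scatter. Compound 3 is estimated at 2200 nM, within 1000 nM to 5000 nM.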

Compound 3, half-maximal inhibitory concentration: 2730 nM
Estimate against measurement, compound 3: 1.2-fold (0.09 log units) below; measured number inside the range.
By their numbers in this assay, from the lowest: compounds 1, 2 and 3 (each within the scatter of the next).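

With phenyl on the carbon with a double bond to nitrogen, this assay gives a 1.5-fold higher number from compound 2 to compound 3 (0.17 log units; within the scatter) and a 1.6-fold higher number from compound 1 to compound 3 (0.21 log units; within the scatter) with neither step separating the compounds. A ring without the bromine, hydroxy or methoxy groups therefore stays within the scatter of both substituted rings, so none of these groups is shown to be required at this place. No measurement at hand accounts for this result.

Open, on these data alone, is whether a phenyl ring carrying an amine or a carboxylic acid at this place would give a step beyond the scatter.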